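Swapping a carboxylic acid chain for a tetrazole chain

The compounds below may be only part of what the source reports. "The series", "measured", "known", "first", "only" and "open" are said of these compounds alone.

Of the compounds shown here, three have been measured in an assay on membranes from lung (Cavia porcellus) for binding affinity to cysteinyl leukotriene receptor (Homo sapiens); on this read-out lower numbers stand for stronger inhibition and higher numbers for weaker inhibition. Compound 1 `c1ccc2nc(COc3ccc(OCCCc4nnn[nH]4)cc3)ccc2c1` gives 69 nM in this assay. Compound 2 `CCCC(CCC(=O)O)Cc1cccc(OCc2ccc3ccccc3n2)c1` gives 50 nM in this assay. Compound 3 `CC(CCCC(=O)O)c1cccc(OCc2ccc3ccccc3n2)c1` gives 90 nM in this assay, the highest of the three numbers, yet the other two values lie within the usual scatter of it, so no order among the three can be claimed. Compound 4 `c1cc(CCCCc2nnn[nH]2)cc(OCc2ccc3ccccc3n2)c1` has not yet been measured. It differs from compound 3 in one place: 4-(1H-tetrazol-5-yl)butyl in place of 4-carboxy-1-methylbutyl on an aromatic carbon. For the measured compounds named here, no measured pair shows this change directly, and compound 1 carries its tetrazole on a different linker. The step in this assay is expected to stay within the scatter, with no clear direction, so the expected step is a 1.3-fold lower number from compound 3 to compound 4 (0.11 log units; within the scatter). Compound 4 is expected to give about 70 nM in this assay, between 25 nM and 200 nM.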

Compound 4, inhibition constant: 20 nM
Compound 4: middle estimate off by 3.5-fold (0.54 log units), on the high side; measured number below the stated range.
By their numbers in this assay, from the lowest: compound 4; then compounds 2, 1 and 3 (each within the scatter of the next).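

On the aromatic carbon, 4-(1H-tetrazol-5-yl)butyl in place of 4-carboxy-1-methylbutyl gives in this assay a 4.5-fold lower number from compound 3 to compound 4 (0.65 log units; beyond the scatter) and so shows the first difference in this set that lies beyond the scatter. Seen against the other acid, 3-(1H-tetrazol-5-yl)propyl in place of 1-(2-carboxyethyl)butyl gives a 2.5-fold lower number from compound 2 to compound 4 (0.40 log units; beyond the scatter) in the same direction. Nothing measured here tells why the number falls. As far as these compounds go, each step changes the branching of the chain along with the acid, so the tetrazole's share remains unknown. A carboxylic acid on the same unbranched butyl chain as compound 4 would separate the two.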